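Chloro in place of bromo on the shared core

The compounds below may be only part of what the source reports. "The series", "measured", "known", "first", "only" and "open" are said of these compounds alone.

In a functional assay on U-373MG ATCC cells (Homo sapiens) for inhibition, read by MTT assay, with a stated time of 72 h (a lower number here means a stronger inhibitor, a higher number a weaker inhibitor), compound 1 (`CC1(C)CC(NC(=S)NCc2ccccc2)c2cc(F)ccc2O1`) gives 27000 nM and compound 2 (`CC1(C)CC(NC(=S)NCc2ccccc2)c2cc(Br)ccc2O1`) gives 29000 nM in the same range, within the scatter of each other. Compound 3 (`CC1(C)CC(NC(=S)NCc2ccccc2)c2cc(Cl)ccc2O1`) differs from compound 2 by chloro in place of bromo on an aromatic carbon. Within the data shown here, the only measured step of this kind, bromo in place of fluoro, is small (a 1.1-fold higher number from compound 1 to compound 2 (0.03 log units; within the scatter)) and lies within the scatter. No change beyond the scatter is therefore expected, and the estimated step is equally small (a 1.0-fold lower number from compound 2 to compound 3 (0.02 log units; within the scatter)). Compound 3 is expected at 28000 nM (estimated range 17000 nM to 45000 nM).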

Compound 3, half-maximal inhibitory concentration: 64000 nM
Compound 3: middle estimate off by 2.3-fold (0.36 log units), on the low side; measured number above the stated range.
By their numbers in this assay, from the lowest: compounds 1 and 2 (each within the scatter of the next); then compound 3.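

Changing the halogen at this position does move the number in this assay: chloro gives a 2.2-fold higher number from compound 2 to compound 3 (0.34 log units; beyond the scatter) and a 2.4-fold higher number from compound 1 to compound 3 (0.37 log units; beyond the scatter), both modest but beyond the scatter. Compound 3 is therefore the weakest of the three, and the chloro compound stands apart from both the fluoro and bromo compounds, so the numbers do not follow the halogen order of fluoro, chloro, bromo. No supporting data bear on why chloro differs.

The compounds shown leave open how a non-halogen group at this position, such as an amine, a methoxy group or a carboxylic acid, would read in this assay.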